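The source may hold more compounds than are shown below. What is called first, only, known or untested is meant among the compounds shown, and "the series" means these compounds.

The measured compounds and their numbers:

Compound 1 `CN1CCN(CC(=O)Nc2nc3ccccc3[nH]2)CC1`: 45%
Compound 2 `O=C(CN1CCN(c2ccccc2F)CC1)Nc1nc2ccccc2[nH]1`: 47.7%
Compound 3 `O=C(CN1CCN(c2ncccn2)CC1)Nc1nc2ccccc2[nH]1`: 46.5%

All three share one core and differ only in the group on an amine nitrogen in a ring. In a functional assay, read by spectrophotometry, with a stated time of 30 min, tested at 100 ug/mL (a lower number here means a weaker effect, a higher number a stronger effect of the compound at the concentration tested), compound 3 gives 46.5%, which is the second highest of the three numbers; its nearest neighbour is compound 2, its furthest compound 1, and both gaps lie within the scatter. The three measured steps are all small: a number 2.7 percentage points higher from compound 1 to compound 2 (within the scatter), a number 1.5 percentage points higher from compound 1 to compound 3 (within the scatter) and a number 1.2 percentage points lower from compound 2 to compound 3 (within the scatter). None of them goes beyond the scatter, so within this small set the group on the ring nitrogen has not shown any effect that can be told apart from noise.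

Compound 4 `COc1ccc(N2CCN(CC(=O)Nc3nc4ccccc4[nH]3)CC2)cc1` has not yet been measured. It differs from compound 3 in one place: 4-methoxyphenyl in place of pyrimidin-2-yl on an amine nitrogen in a ring. Among the measured compounds shown here, since every change at this position so far has stayed within the scatter, no step beyond the scatter is expected in this assay for this change either; the expected step is a number 0.5 percentage points higher from compound 3 to compound 4 (within the scatter). Compound 4 is therefore estimated to give 47%, with a range from 37% to 57%.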

Compound 4, a percentage reported as activity, at one concentration (the size of the read-out at that concentration, not a potency): 38.9%
The estimate for compound 4 lay 8.1 percentage points above the measured number; the measured number falls inside the stated range.
By their numbers in this assay, from the lowest: compounds 4, 1, 3 and 2 (each within the scatter of the next).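

In this assay, among the compounds shown here, the change to 4-methoxyphenyl gives a number 7.6 percentage points lower from compound 3 to compound 4 (within the scatter) and a number 8.8 percentage points lower from compound 2 to compound 4 (within the scatter) and also a number 6.1 percentage points lower from compound 1 to compound 4 (within the scatter) and these three steps are each larger in size than any step among the earlier compounds, yet none of them goes beyond the scatter. Four groups, methyl, 2-fluorophenyl, pyrimidin-2-yl and 4-methoxyphenyl, have now stood on this amine nitrogen in a ring, and the wider spread of steps still gives no difference between any two of them that can be told apart from noise, so the result adds size to the steps at this position but no ranking of the groups. Nothing measured here bears on why the steps to compound 4 are the largest so far.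

The compounds shown leave open whether any group on this nitrogen can move the read-out beyond the scatter, for example a carboxylic acid on a longer chain, a primary amine or a 2-methoxyphenyl group. They also leave open whether the picture would hold at other concentrations, as each compound is represented by a single read-out at one concentration.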